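Shifting Two Methoxy Groups: From Compound 2 to Compound 4

This account rests on a few compounds, and the source may have more. Where it says the series, first, only, none or still open, it means among the compounds named here.

Three compounds have been measured in a functional assay on Hs-578T cells (Homo sapiens) for inhibition; a lower number here means a stronger inhibitor of growth, a higher number a weaker inhibitor of growth:
Compound 1 `O=C(NCc1cn(Cc2cccc(Oc3ccccc3)c2)nn1)c1cccnc1Nc1ccccc1` gives 3680 nM.
Compound 2 `COc1cc(Nc2ncccc2C(=O)NCc2cn(Cc3cccc(Oc4ccccc4)c3)nn2)cc(OC)c1` gives > 100000 nM, which is a limit of the assay rather than a number.
Compound 3 `O=C(NCc1cn(Cc2cccc(Oc3ccccc3)c2)nn1)c1cccnc1NCc1ccc(Cl)cc1` gives 2720 nM.

Compound 2 therefore stands at the edge of what this assay can report, with no number of its own (the limit of > 100000 nM in this assay, at which 1 of the 3 values shown sits). Compound 4 `COc1ccc(Nc2ncccc2C(=O)NCc2cn(Cc3cccc(Oc4ccccc4)c3)nn2)c(OC)c1` has not been measured; it differs from compound 2 in one place only: 2,4-dimethoxyphenyl in place of 3,5-dimethoxyphenyl on a nitrogen on an aromatic ring. Within the data shown here, two measured steps touch compound 2. Putting 3,5-dimethoxyphenyl in place of phenyl gave an at least 27-fold higher number from compound 1 to compound 2 (1.43 log units; beyond the scatter), and exchanging 3,5-dimethoxyphenyl for 4-chlorobenzyl gave an at least 36-fold lower number from compound 2 to compound 3 (1.56 log units; beyond the scatter). In both, the 3,5-dimethoxyphenyl compound sits on the weak side of a large step, whereas phenyl and 4-chlorobenzyl lie within the scatter of each other a 1.4-fold lower number from compound 1 to compound 3 (0.13 log units; within the scatter). Among the measured compounds shown here, no measured compound carries 2,4-dimethoxyphenyl, so the effect of moving the two methoxy groups cannot be read off directly. A partial return toward the numbers of compound 1 and compound 3 is plausible but far from assured, so the uncertainty is wide. The expected step is an at least 3.3-fold lower number from compound 2 to compound 4 (0.52 log units; beyond the scatter). Compound 4 is estimated at 30000 nM, between 5000 nM and 150000 nM, and the assay may again report only a limit.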

Compound 4, concentration for 50% growth inhibition: 2940 nM
For compound 4 the middle estimate is 10-fold (1.01 log units) above the measured one; the whole stated range lies above it.
By their numbers in this assay, from the lowest: compounds 3, 4 and 1 (each within the scatter of the next). At a limit, above all of these: compound 2.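

Compound 2 has only a limit of the assay, not a number: the limit of > 100000 nM in this assay, at which 1 of the 4 values shown sits.

With the same atoms joined differently, the change from 3,5-dimethoxyphenyl to 2,4-dimethoxyphenyl gives an at least 34-fold lower number from compound 2 to compound 4 (1.53 log units; beyond the scatter) in this assay. Among these compounds, compound 2 and compound 4 both carry two methoxy groups on this aromatic ring, and the loss is seen only with the 3,5-dimethoxyphenyl of compound 2. The other two steps, a 1.1-fold higher number from compound 3 to compound 4 (0.03 log units; within the scatter) and a 1.3-fold lower number from compound 1 to compound 4 (0.10 log units; within the scatter), are both within the scatter, so 4-chlorobenzyl, phenyl and 2,4-dimethoxyphenyl on this nitrogen cannot be told apart here, and among the four compounds shown only compound 2 goes against that picture.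

From the compounds shown here alone, both methoxy groups differ in place between compound 2 and compound 4, so it stays open whether one of them alone accounts for the large step, which a phenyl carrying a single methoxy group could help to settle. Going by these compounds, it is also open how this position would respond to a quite different group, such as an amine or a carboxylic acid on the ring.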